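Swapping an Ortho Chloro for Methoxy on a Dienone

This account rests on a few compounds, and the source may have more. Where it says the series, first, only, none or still open, it means among the compounds named here.

Measured compounds:
- Compound 1, `CC1=C(/C=C/C(=O)/C=C/c2ccccc2)C(C)(C)CCC1`: 10600 nM
- Compound 2, `CC1=C(/C=C/C(=O)/C=C/c2ccccc2Cl)C(C)(C)CCC1`: 54600 nM

These two compounds share a core and differ only on the phenyl ring. For the measured compounds named here, in a functional assay on MCF7 cells (Homo sapiens) for cytotoxicity, read by sulforhodamine B assay, with a stated time of 48 h (on this read-out higher numbers stand for weaker inhibition and lower numbers for stronger inhibition), compound 1 gives 10600 nM, while compound 2 gives 54600 nM, the highest of the two numbers; the one step between them, a 5.2-fold higher number from compound 1 to compound 2 (0.71 log units; beyond the scatter), shows that adding chloro on the aromatic carbon weakened inhibition.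

Compound 3, `COc1ccccc1/C=C/C(=O)/C=C/C1=C(C)CCCC1(C)C`, is not yet measured. Relative to compound 2 the change is methoxy in place of chloro on an aromatic carbon. Going by the values given here, no measured step replaces chloro with methoxy, so only the chloro step bears on this change, and it lies in the direction of weaker inhibition. Since methoxy is a different group, its effect cannot be read from that single step. Compound 3 is therefore expected to fall between compound 1 and compound 2, a step of a 2.2-fold lower number from compound 2 to compound 3 (0.34 log units; beyond the scatter) in this assay, with an estimate of 25000 nM and a range from 8000 nM to 80000 nM.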

Compound 3, half-maximal inhibitory concentration: 13400 nM
Beside the measured number, compound 3's estimate is 1.9-fold (0.27 log units) above it; the range from low to high includes it.
By their numbers in this assay, from the lowest: compounds 1 and 3 (each within the scatter of the next); then compound 2.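

At this place on the aromatic ring, ortho to a large group, the identity of the group matters: in this assay, the change from chloro to methoxy gives a 4.1-fold lower number from compound 2 to compound 3 (0.61 log units; beyond the scatter). The weaker inhibition seen with chloro is therefore not shared by every replacement of hydrogen here. Methoxy in place of hydrogen gives a 1.3-fold higher number from compound 1 to compound 3 (0.10 log units; within the scatter), so methoxy, with 2 heavy atoms against 1 for chloro, causes no readable change from compound 1, and the heavy-atom count alone does not account for these numbers.

Going by these compounds, whether an amine or a carboxylic acid at this place would behave like chloro or like methoxy remains open. Nothing measured here explains the difference between chloro and methoxy.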